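A few compounds are considered here, and "the series" means these few. Any claim that something is new, unique, unknown or untested is made for them only; others in the source may bear on it.

Series notes on the shared core, read-out an assay (Rattus norvegicus) for inhibition of Fatty-acid amide hydrolase 1 (Homo sapiens); on this read-out lower numbers stand for stronger inhibition and higher numbers for weaker inhibition.

compound 1 `COc1ccnc(-c2cnc(C(=O)CCCCCCc3ccccc3)o2)c1`: compound 1 gives 0.8 nM
compound 2 `CNC(=O)c1cnc(C(=O)CCCCCCc2ccccc2)o1`: compound 2 gives 7 nM
compound 3 `CC(=O)c1cnc(C(=O)CCCCCCc2ccccc2)o1`: compound 3 gives 2 nM

All three keep the core and the phenyl-terminated chain and differ only in the group on the aromatic carbon of the five-membered ring. Compound 3 stands second highest of the three numbers: the step of a 2.5-fold higher number from compound 1 to compound 3 (0.40 log units; beyond the scatter) and the step of a 3.5-fold lower number from compound 2 to compound 3 (0.54 log units; beyond the scatter) are both beyond the scatter, but modest. The widest span seen at this position is an 8.8-fold higher number from compound 1 to compound 2 (0.94 log units; beyond the scatter), again modest.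

Compound 4 `O=C(CCCCCCc1ccccc1)c1ncc(F)o1` is not yet measured in this assay. It differs from compound 3 by fluoro in place of acetyl on an aromatic carbon. Among the measured compounds shown here, the steps that bear on it are the ones that already vary this same position, a 2.5-fold higher number from compound 1 to compound 3 (0.40 log units; beyond the scatter) and a 3.5-fold lower number from compound 2 to compound 3 (0.54 log units; beyond the scatter); neither goes beyond a modest size, so the expectation for compound 4 is likewise a modest step, and with the acetyl and its hydrogen-bond acceptor gone the number is expected to rise rather than fall: a 3.0-fold higher number from compound 3 to compound 4 (0.48 log units; beyond the scatter). The estimate for compound 4 in this assay is 6 nM, with a range from 2 nM to 20 nM.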

Compound 4, inhibition constant: 30 nM
Beside the measured number, compound 4's estimate is 5.0-fold (0.70 log units) below it; measured number above the stated range.
By their numbers in this assay, from the lowest: compound 1; then compound 3; then compound 2; then compound 4.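

In this assay, among the compounds shown here, fluoro in place of acetyl is the first large change among single swaps of the group on this aromatic carbon: the step is a 15-fold higher number from compound 3 to compound 4 (1.18 log units; beyond the scatter) and goes well past the widest earlier one, an 8.8-fold higher number from compound 1 to compound 2 (0.94 log units; beyond the scatter), which stayed modest. Fluoro also falls behind compound 2, the weakest of the earlier three, with a 4.3-fold higher number from compound 2 to compound 4 (0.63 log units; beyond the scatter), and the distance from the pyridine-bearing compound grows to a 38-fold higher number from compound 1 to compound 4 (1.57 log units; beyond the scatter), so this position tolerates acetyl, methylcarbamoyl and 4-methoxypyridin-2-yl far better than fluoro. Nothing at hand accounts for this rise.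

The swap removes heavy atoms and a hydrogen-bond acceptor together, so the compounds shown do not separate these two changes; a nitrile or a methyl ester in this place, set beside chloro or a bare hydrogen, would bear on that question. From the compounds shown here alone, how a carboxylic acid or an amine would rank here also stays open, as does whether the same order holds on a shorter chain.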